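Aryl swap on the double-bonded chain: compound 2 to compound 3

The source may hold more compounds than are shown below. What is called first, only, known or untested is meant among the compounds shown, and "the series" means these compounds.

Within the data shown here, in a functional assay on DU-145 cells (Homo sapiens) for inhibition, read by trypan blue exclusion, with a stated time of 96 h (a higher number here means a weaker inhibitor of growth, a lower number a stronger inhibitor of growth), compound 2 (`Cc1ccc(CS(=O)(=O)/C(=C/c2cc(C)ccc2C)C(=O)c2ccc(Cl)cc2)cc1`) holds the lower of the two numbers so far with 1000 nM against compound 1 (`Cc1ccc(CS(=O)(=O)/C(=C/c2ccc(N(C)C)cc2)C(=O)c2ccc(Cl)cc2)cc1`) at 50000 nM. Compound 3 (`Cc1ccc(CS(=O)(=O)/C(=C/c2ccccc2Br)C(=O)c2ccc(Cl)cc2)cc1`) has 2-bromophenyl in place of 2,5-dimethylphenyl on a double-bonded chain carbon bound to a double-bonded chain carbon. Among the measured compounds shown here, one measured step bears on this change: a 50-fold lower number from compound 1 to compound 2 (1.70 log units; beyond the scatter), large and beyond the scatter, with 2,5-dimethylphenyl in place of 4-(dimethylamino)phenyl at the same place. For the measured compounds named here, it shows that the group here can move this assay strongly, but no compound with 2-bromophenyl has been measured, so it sets no direction for this change. Only a small shift, within the scatter, is expected: a 1.5-fold higher number from compound 2 to compound 3 (0.18 log units; within the scatter). For compound 3 the estimated value is 1500 nM, with an expected range of 400 nM to 6000 nM.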

Compound 3, concentration for 50% growth inhibition: 25000 nM
For compound 3 the middle estimate is 17-fold (1.22 log units) below the measured one; measured number outside the range, above it.
By their numbers in this assay, from the lowest: compound 2; then compounds 3 and 1 (each within the scatter of the next).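

In this assay, the step of a 25-fold higher number from compound 2 to compound 3 (1.40 log units; beyond the scatter) shows that this place responds strongly even between two groups with matching counts: 2-bromophenyl and 2,5-dimethylphenyl each bring one six-membered aromatic ring of carbon only, no hydrogen-bond donors or acceptors and no net charge. The high number of compound 1 therefore does not mark 4-(dimethylamino)phenyl as a uniquely poor group, since a 2.0-fold lower number from compound 1 to compound 3 (0.30 log units; within the scatter) leaves compound 3 and compound 1 within the scatter of each other. Among the three compounds, only compound 2 stands apart.

Still open, from the compounds shown here alone, is whether plain phenyl or a 2-methylphenyl group at this place would stay with compound 2 or fall with compound 3, which would separate the two methyl groups from the bromine. No measurement at hand accounts for the gap between these groups.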